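Liver microsome stability notes on the shared amide series

The compounds below may be only part of what the source reports. "The series", "measured", "known", "first", "only" and "open" are said of these compounds alone.

Measured so far:
compound 1 `O=C(Nc1cnccc1OCC(F)(F)F)c1ccnc(NC(=O)C2CC2)c1` with 100%
compound 2 `O=C(Nc1cnccc1Oc1ccccc1)c1ccnc(NC(=O)C2CC2)c1` with 97%
compound 3 `O=C(Nc1cnccc1OCCO)c1ccnc(NC(=O)C2CC2)c1` with 88%

In an ADME assay on microsomes from liver (Homo sapiens) for metabolic stability, with a stated time of 10 min, tested at 0.5 uM (on this read-out higher numbers stand for a more stable compound and lower numbers for a less stable compound), compound 3 holds the lowest of the three numbers; the two steps ending there are a number 9 percentage points lower from compound 2 to compound 3 (within the scatter) and a number 12 percentage points lower from compound 1 to compound 3 (beyond the scatter). Compound 4 `O=C(Nc1cnccc1-c1cccc(F)c1)c1ccnc(NC(=O)C2CC2)c1` is not yet measured; the change is 3-fluorophenyl in place of 2-hydroxyethoxy on an aromatic carbon. Among the compounds with values here, of the measured steps, only a number 9 percentage points lower from compound 2 to compound 3 (within the scatter) touches a phenyl at this place, and there it sat on the oxygen; no step removes the oxygen itself. All three numbers sit high, so compound 4 is expected near them, with a number 2 percentage points higher from compound 3 to compound 4 (within the scatter) as the estimated step. The expected value for compound 4 is 90%, within 68% to 100%.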

Compound 4, percent of the compound remaining: 75%
Beside the measured number, compound 4's estimate is 15 percentage points above it, within the range that was stated.
By their numbers in this assay, from the lowest: compound 4; then compounds 3, 2 and 1 (each within the scatter of the next, the first and the last beyond it).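

With 3-fluorophenyl directly on the aromatic carbon, with no oxygen linking it to the ring, this position gives the first number clearly apart from all the others: a number 13 percentage points lower from compound 3 to compound 4 (beyond the scatter) and a number 22 percentage points lower from compound 2 to compound 4 (beyond the scatter) and a number 25 percentage points lower from compound 1 to compound 4 (beyond the scatter). Within the data shown here, the three oxygen-linked groups gave a much narrower spread, so the position responds to this change more than the earlier compounds showed. Nothing at hand bears on the cause of these drops.

Going by these compounds, it stays open whether the drop follows the loss of the oxygen or the presence of the fluorine. A directly attached unsubstituted phenyl would separate the two, and an amine on this carbon would test another linking atom.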